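Hydroxy to Hydrogen on a Macrocyclic Depsipeptide Side Chain

A few compounds are considered here, and "the series" means these few. Any claim that something is new, unique, unknown or untested is made for them only; others in the source may bear on it.

Compound 1, `CC[C@H](C)[C@H]1C(=O)N[C@H](Cc2ccc(O)c(Br)c2)C(=O)N[C@@H](C(C)(C)O)C(=O)O[C@H](c2ccccc2)[C@H](C)/C=C/C=C(\C)[C@H](OC)C[C@@H]2O[C@@]2(C)C(=O)N1C`, gives 9.61 nM in a functional assay on PANC-1 cells (Homo sapiens) for antiproliferative activity; on this read-out higher numbers stand for weaker inhibition and lower numbers for stronger inhibition.
Compound 2, `CC[C@H](C)[C@H]1C(=O)N[C@H](Cc2cc(Cl)c(O)c(Cl)c2)C(=O)N[C@@H](C(C)C)C(=O)O[C@H](c2ccccc2)[C@H](C)/C=C/C=C(\C)[C@H](OC)C/C=C(\C)C(=O)N1C`, gives 137 nM in this assay.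
Compound 3, `CC[C@H](C)[C@H]1C(=O)N[C@H](Cc2cc(Cl)c(O)c(Cl)c2)C(=O)N[C@@H](C(C)(C)O)C(=O)O[C@H](c2ccccc2)[C@H](C)/C=C/C=C(\C)[C@H](OC)C/C=C(\C)C(=O)N1C`, gives 11.3 nM in this assay.

Compound 3 and compound 2 share one core and differ in a single place: hydrogen in place of hydroxy on a saturated chain carbon bound to two saturated chain carbons and a saturated ring carbon. That change produces a 12-fold higher number from compound 3 to compound 2 (1.08 log units; beyond the scatter). Compound 1 rests on a different core; the difference between the two cores is not broken down here. The values of compound 1 and compound 3 lie within the scatter of each other.

Compound 4, `CC[C@H](C)[C@H]1C(=O)N[C@H](Cc2ccc(O)c(Br)c2)C(=O)N[C@@H](C(C)C)C(=O)O[C@H](c2ccccc2)[C@H](C)/C=C/C=C(\C)[C@H](OC)C[C@@H]2O[C@@]2(C)C(=O)N1C`, has not yet been measured. It differs from compound 1 by hydrogen in place of hydroxy on a saturated chain carbon bound to two saturated chain carbons and a saturated ring carbon, the same change seen between compound 3 and compound 2, at a place described in the same words. Since that one example gave a 12-fold higher number from compound 3 to compound 2 (1.08 log units; beyond the scatter), a step of similar size is expected here, a 12-fold higher number from compound 1 to compound 4 (1.08 log units; beyond the scatter). Compound 4 is therefore estimated at 115 nM, most likely between 40 nM and 350 nM.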

Compound 4, half-maximal inhibitory concentration: 15.7 nM
Compound 4: the middle estimate sits 7.3-fold (0.86 log units) above what was measured; the whole stated range lies above it.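

In this assay the change from 1-hydroxy-1-methylethyl to isopropyl gives a 1.6-fold higher number from compound 1 to compound 4 (0.21 log units; within the scatter) on the core of compound 1. The same change therefore does not carry over in size from one core to the other: the same change on two cores in this assay, a 12-fold higher number (1.08 log units; beyond the scatter) from compound 3 to compound 2 and a 1.6-fold higher number (0.21 log units; within the scatter) from compound 1 to compound 4, 7.4-fold (0.87 log units) apart, beyond the scatter of two such steps. This shows that a single example on one core was a poor guide to the step on the other, but two pairs do not show which feature of the cores goes with the difference, or how the change would behave on any further core.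

The compounds shown leave open what an amine or a methoxy group would do in place of the hydroxy. Within the data shown here, they also include no pair that separates the differences between the two cores one at a time.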